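The compounds below may be only part of what the source reports. "The series", "measured", "known", "first", "only" and "open" are said of these compounds alone.

Measured in a functional assay on U-118-MG cells (Homo sapiens) for cytotoxicity, read by MTT assay, with a stated time of 48 h; a lower number here means a stronger inhibitor, a higher number a weaker inhibitor:
- Compound 1 `C[n+]1cccc(OP(=O)([O-])OC[C@H]2O[C@@H](n3cc(F)c(=O)[nH]c3=O)C[C@@H]2OC(=O)c2ccccc2)c1`: 3150 nM
- Compound 2 `O=C(O[C@H]1C[C@H](n2cc(F)c(=O)[nH]c2=O)O[C@@H]1COP(=O)([O-])Oc1ccc[n+](Cc2ccccc2)c1)c1ccccc1`: 1470 nM
- Compound 3 `CCOC(=O)C[n+]1cccc(OP(=O)([O-])OC[C@H]2O[C@@H](n3cc(F)c(=O)[nH]c3=O)C[C@@H]2OC(=O)c2ccccc2)c1`: 1540 nM

Compound 3 holds the second highest of the three numbers. Its nearest neighbour is shown by a 1.0-fold higher number from compound 2 to compound 3 (0.02 log units; within the scatter), and its furthest by a 2.0-fold lower number from compound 1 to compound 3 (0.31 log units; beyond the scatter).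

Compound 4 `C[N+]1(C)CCC(OP(=O)([O-])OC[C@H]2O[C@@H](n3cc(F)c(=O)[nH]c3=O)C[C@@H]2OC(=O)c2ccccc2)CC1` is the next step, with a group of 8 heavy atoms (7 carbon, 1 nitrogen; one six-membered non-aromatic ring with 1 hetero atom) in place of a group of 12 heavy atoms (9 carbon, 1 nitrogen, 2 oxygen; one six-membered aromatic ring with 1 hetero atom), on an oxygen. The place of the change is an oxygen whose other neighbours are: phosphorus.

Among the compounds with values here, no measured step replaces the ring itself, so the evidence is indirect. The measured steps only change the group on the aromatic nitrogen, and they are modest: phenyl gives a 2.1-fold lower number from compound 1 to compound 2 (0.33 log units; beyond the scatter), and ethoxycarbonyl gives the step already noted from compound 1. Compound 4 carries neither phenyl nor ethoxycarbonyl, and the same holds for compound 1 at 3150 nM. A modest move to a higher number is therefore expected, though the new ring adds real uncertainty.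

The estimated change is a 1.9-fold higher number from compound 3 to compound 4 (0.29 log units; within the scatter). Compound 4 is expected at 3000 nM, with an estimated range of 1200 nM to 8000 nM.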

Compound 4, half-maximal inhibitory concentration: 4420 nM
Compound 4: the middle estimate sits 1.5-fold (0.17 log units) below what was measured; the measured number falls inside the stated range.
By their numbers in this assay, from the lowest: compounds 2 and 3 (each within the scatter of the next); then compounds 1 and 4 (each within the scatter of the next).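

In this assay, within the data shown here, the saturated ring group on the oxygen bound to phosphorus gives a 2.9-fold higher number from compound 3 to compound 4 (0.46 log units; beyond the scatter) as the first measured change of the ring itself, though this step also removes the ethoxycarbonyl group. The comparison with the unsubstituted chain is a 1.4-fold higher number from compound 1 to compound 4 (0.15 log units; within the scatter) and lies within the scatter, so among these compounds the aromatic ring and the saturated ring group, both with net charge +1, are not separated at this place. No measurement shown here explains this result.

As far as these compounds go, it remains open whether phenyl or ethoxycarbonyl on the saturated ring group would give numbers like those of compounds 2 and 3. From the compounds shown here alone, the effect of an uncharged amine at this place, or of a carboxylic acid in place of the ethoxycarbonyl group, also remains open.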